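From Ethyl Ester to Free Acid on One Core

A few compounds are considered here, and "the series" means these few. Any claim that something is new, unique, unknown or untested is made for them only; others in the source may bear on it.

Compound 1, `CN1CCN(C(=O)/C=C/c2ccncc2-c2ccc3ccccc3c2)CC1`: 43.6 nM
Compound 2, `CNC(=O)/C=C/c1ccncc1-c1ccc2ccccc2c1`: 12.4 nM
Compound 3, `CCOC(=O)/C=C/c1ccncc1-c1ccc2ccccc2c1`: 53.3 nM

These three compounds share one core and differ only in the group attached to the carbonyl carbon. All were tested in an assay on a protein complex for inhibition of CDK8/Cyclin C (Homo sapiens), with a stated time of 1 h; a lower number here means a stronger inhibitor, a higher number a weaker inhibitor. For the measured compounds named here, compound 3 has the highest number of the three, but its standing is mixed: the step of a 1.2-fold higher number from compound 1 to compound 3 (0.09 log units; within the scatter) stays within the scatter, so compound 1 and compound 3 cannot be told apart, whereas the step of a 4.3-fold higher number from compound 2 to compound 3 (0.63 log units; beyond the scatter) lies beyond it, and compound 2 is the one compound clearly ahead. The third measured step, a 3.5-fold lower number from compound 1 to compound 2 (0.55 log units; beyond the scatter), is of similar modest size.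

Compound 4, `O=C(O)/C=C/c1ccncc1-c1ccc2ccccc2c1`, differs from compound 3 by hydrogen in place of ethyl on an oxygen next to a carbonyl group. Going by the values given here, no measured step makes this particular change, so there is no direct precedent. What the three steps do show is that exchanging the group on the carbonyl carbon has so far moved the number in this assay by modest amounts in either direction, never by a large jump. On that basis compound 4 is expected to land close to compound 3, with a step of a 1.5-fold higher number from compound 3 to compound 4 (0.18 log units; within the scatter) that could fall on either side of the scatter. The estimate for compound 4 is 80 nM, with a range from 25 nM to 300 nM.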

Compound 4, half-maximal inhibitory concentration: 5 nM
Beside the measured number, compound 4's estimate is 16-fold (1.20 log units) above it, and the stated range ends above it.
By their numbers in this assay, from the lowest: compound 4; then compound 2; then compounds 1 and 3 (each within the scatter of the next).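

For the compounds shown here, replacing ethyl with hydrogen on the oxygen next to a carbonyl group, which turns ethoxycarbonyl into carboxy, produces the first large step in this assay (an 11-fold lower number from compound 3 to compound 4 (1.03 log units; beyond the scatter)). The earlier exchanges on the carbonyl carbon were modest or lay within the scatter, so this position can move the number further than they showed. Hydroxy on the carbonyl carbon also beats the two other groups, with hydroxy in place of methylamino (a 2.5-fold lower number from compound 2 to compound 4 (0.39 log units; beyond the scatter)) and hydroxy in place of 4-methylpiperazin-1-yl (an 8.7-fold lower number from compound 1 to compound 4 (0.94 log units; beyond the scatter)), so compound 4 now stands clearly ahead of compound 1, compound 2 and compound 3.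

Going by these compounds, whether the carboxy group alone gives this low number stays open, and an amino group or a methoxy group on the carbonyl carbon would help to show how far the result depends on that exact group. The compounds shown come with no measurement that explains the large step.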